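Carboxyphenyl variation on the shared core

This account rests on a few compounds, and the source may have more. Where it says the series, first, only, none or still open, it means among the compounds named here.

Of the compounds shown here, two have numbers so far. Compound 1 `Cn1sc2cc(OCc3cccc(-c4ccc(Cl)c(C(=O)O)c4)c3)ccc2c1=O` and compound 2 `COc1ccc(C(=O)O)cc1-c1cccc(COc2ccc3c(c2)CN(C2CCCC2)C3=O)c1` share the same core, differing in the substituted phenyl ring and its carboxylic acid. In an assay on HEK293 cells for positive allosteric modulation of metabotropic glutamate receptor 2 (Rattus norvegicus), read by thallium flux (a higher number here means a larger maximal response, a lower number a smaller maximal response), compound 1 gives 74.7%, and compound 2 gives 79.2%. The gap between compound 2 and compound 1 lies within the usual scatter, so the two numbers cannot be told apart and no ordering is claimed.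

Compound 3 `O=C(O)c1cc(F)cc(-c2cccc(COc3ccc4c(c3)CN(C3CCCC3)C4=O)c2)c1` is next and differs from compound 2 as follows: 3-carboxy-5-fluorophenyl in place of 5-carboxy-2-methoxyphenyl on an aromatic carbon. Going by the values given here, no measured step of this kind exists, so nothing beyond the two values is known about such a change.

The expectation for compound 3 in this assay is a step of a number 7.2 percentage points lower from compound 2 to compound 3 (within the scatter), that is, no change beyond the scatter or a slight decrease. Compound 3 is estimated at 72%, with a range from 55% to 88%.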

Compound 3, largest response reached (reported as percent of maximum), in percent of the reference or control that the assay uses: 80.8%
Compound 3: middle estimate off by 8.8 percentage points, on the low side; low and high end bracket the measured number.
By their numbers in this assay, from the lowest: compounds 1, 2 and 3 (each within the scatter of the next).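

In this assay, going by these compounds alone, the replacement of 5-carboxy-2-methoxyphenyl by 3-carboxy-5-fluorophenyl, meta to a large group, gives a number 1.6 percentage points higher from compound 2 to compound 3 (within the scatter), the first single-place step at this position. Both groups carry a carboxylic acid, so the maximal response holds within the scatter when the methoxy group leaves, a fluorine enters and the carboxy group takes a different place on the ring, though this one step cannot separate those three changes. No data on hand bear on why the response holds.

Open, from the compounds shown here alone, is whether this position needs a carboxylic acid at all, which a tetrazole or a primary amide in its place would test. Also open, going by these compounds, is how a 3-carboxyphenyl ring with no fluorine, or with a methoxy group in place of the fluorine, would compare with compound 3.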